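The source may report more compounds than this note shows. Statements on the series, on what has been measured and on what is new or still open speak of the compounds shown alone.

Three compounds share one core and differ only in the aromatic group that sits ortho to the two cyano groups. Compound 1 is `N#Cc1c(-c2ccccc2)c(C#N)c(=O)n(/N=C/c2cn(-c3ccccc3)nc2-c2ccccc2)c1N`. In an ADME assay on HeLa cells (Homo sapiens) for cytotoxicity, read by MTT assay (a lower number here means a stronger inhibitor, a higher number a weaker inhibitor), compound 1 gives > 200 ug/mL, which is a limit of the assay and not a number. Compound 2 is `N#Cc1c(-c2ccc(Cl)cc2)c(C#N)c(=O)n(/N=C/c2cn(-c3ccccc3)nc2-c2ccccc2)c1N`. In this assay compound 2 gives > 200 ug/mL, again a limit. Compound 3 is `COc1cc(-c2c(C#N)c(N)n(/N=C/c3cn(-c4ccccc4)nc3-c3ccccc3)c(=O)c2C#N)cc(OC)c1OC`. In this assay compound 3 gives > 200 ug/mL, also a limit, so compound 3 stands at the same boundary as the other two: the limit of > 200 ug/mL in this assay, at which 3 of the 3 values shown sit. The steps a step that the two limits leave unreadable from compound 1 to compound 2, a step that the two limits leave unreadable from compound 1 to compound 3 and a step that the two limits leave unreadable from compound 2 to compound 3 are therefore all unreadable in size.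

Compound 4 is `N#Cc1c(-c2ccc([N+](=O)[O-])cc2)c(C#N)c(=O)n(/N=C/c2cn(-c3ccccc3)nc2-c2ccccc2)c1N`. It differs from compound 3 in one place: 4-nitrophenyl in place of 3,4,5-trimethoxyphenyl on an aromatic carbon. For the measured compounds named here, none of the measured steps gives a readable size, so no direction is expected beyond the scatter. Compound 4 is expected to sit at 300 ug/mL, between 100 ug/mL and 1000 ug/mL, most likely reported again as a limit. The expected step from compound 3 is a step that the limit leaves unreadable from compound 3 to compound 4.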

Compound 4, half-maximal inhibitory concentration: > 200 ug/mL
Compound 4 was reported as a limit; the forecaster's own chance of this, stated with the estimate: 80%; the middle value is on the limit's open side.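

Compound 4 also ends at a limit, so no step among compound 1, compound 2, compound 3 and compound 4 can be read in size: the limit of > 200 ug/mL in this assay, at which 4 of the 4 values shown sit.

The compounds shown leave open whether these aromatic groups differ at all in this assay.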